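The source may report more compounds than this note shows. Statements on the series, on what has been measured and on what is new or still open speak of the compounds shown alone.

Measured compounds:
- compound 1 `NNC(=O)c1c(NC(=O)NS(=O)(=O)c2ccccc2)sc2c1CCCCC2` — 2800 nM
- compound 2 `CN1CCN(C(=O)c2c(NC(=O)NS(=O)(=O)c3ccccc3)sc3c2CCCCC3)CC1` — > 100000 nM, a limit of the assay

Going by the values given here, in a functional assay on UACC-257 cells (Homo sapiens) for inhibition, with a stated time of 48 h (on this read-out lower numbers stand for stronger inhibition of growth and higher numbers for weaker inhibition of growth), compound 1 gives 2800 nM, the only number among the values shown. Compound 2, the remaining one, reaches only the limit (the limit of > 100000 nM in this assay, at which 1 of the 2 values shown sits). Among the compounds with values here, the single measured step, an at least 35-fold higher number from compound 1 to compound 2 (1.55 log units; beyond the scatter), changes the substituent on the carbonyl carbon and removes the aminoamino group entirely.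

Compound 3 `O=C(Nc1sc2c(c1C(=O)NNc1ccc(Cl)cc1)CCCCC2)NS(=O)(=O)c1ccccc1` differs from compound 1 by 4-chlorophenyl in place of hydrogen on an amine nitrogen. The aminoamino linkage is kept and only its terminal amine is capped. The measured step bears on this change only indirectly: it shows that loss of the aminoamino group is costly, but it does not test a substituted hydrazide. The expectation is therefore a weakening in this assay smaller than the measured step, with wide uncertainty. Compound 3 is estimated at 9000 nM, between 2000 nM and 50000 nM. The expected step is a 3.2-fold higher number from compound 1 to compound 3 (0.51 log units; beyond the scatter).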

Compound 3, concentration for 50% growth inhibition: > 100000 nM
Compound 3 was reported as a limit (the forecaster's own chance of this, stated with the estimate: 25%); at least 11-fold (1.04 log units) between middle value and limit.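

In this assay, the step of an at least 35-fold higher number from compound 1 to compound 3 (1.55 log units; beyond the scatter) shows that keeping the aminoamino linkage is not enough to retain growth inhibition. With 4-chlorophenyl on the amine nitrogen, the substituted hydrazide falls as far as the assay can show, so this one change is as costly here as replacing the whole aminoamino group with 4-methylpiperazin-1-yl. The value of compound 3 is a limit, as is that of compound 2, so the step between them cannot be read and the two cannot be ranked: the limit of > 100000 nM in this assay, at which 2 of the 3 values shown sit.

From the compounds shown here alone, it remains open whether a smaller group on this amine nitrogen, such as methyl, or an unsubstituted phenyl ring would be tolerated. The compounds shown also cannot separate the contribution of the chlorine from that of the phenyl ring.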